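From 4-methylbenzyl to cyclopropyl on the amine nitrogen

The compounds below may be only part of what the source reports. "The series", "measured", "known", "first", "only" and "open" are said of these compounds alone.

Measured in a functional assay on DLD-1 cells (Homo sapiens) for inhibition, read by MTT assay, with a stated time of 72 h; on this read-out lower numbers stand for stronger inhibition and higher numbers for weaker inhibition:
- compound 1 `COc1cc(Oc2cccc(Nc3ccccc3)c2)cc(OC)c1CNCc1ccc(C)cc1` gives 6080 nM
- compound 2 `COc1ccc([C@@H](C)NCc2c(OC)cc(Oc3cccc(Nc4ccccc4)c3)c(OC)c2OC)cc1` gives 3500 nM
- compound 3 `COc1cc(Oc2cccc(Nc3ccccc3)c2)cc(OC)c1CN(C)C` gives > 20000 nM

Compound 1 and compound 2 lie within the usual scatter of each other, so neither ranks ahead. For compound 3, the entry > 20000 nM is a limit of the assay and not a number.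

Compound 4 `COc1cc(Oc2cccc(Nc3ccccc3)c2)cc(OC)c1CNC1CC1` has not yet been measured. It swaps the group on the amine nitrogen of compound 1 (cyclopropyl in place of 4-methylbenzyl on an amine nitrogen) and so, like compound 3, loses the 4-methylbenzyl group.

Among the compounds with values here, one measured step bears on this: an at least 3.2-fold higher number from compound 1 to compound 3 (0.51 log units; beyond the scatter) is beyond the scatter, with dimethylamino taking the place of (4-methylbenzyl)amino. Within the data shown here, it is the only guide, and it involves a different replacement group. On that basis, weaker inhibition is expected, with an estimated step of a 2.5-fold higher number from compound 1 to compound 4 (0.39 log units; beyond the scatter) in this assay as the likely outcome. Compound 4 is expected at 15000 nM with an estimated range between 6000 nM and 40000 nM as its likely span.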

Compound 4, half-maximal inhibitory concentration: > 20000 nM
Compound 4: no number, only a limit; the forecaster's own chance of this, stated with the estimate: 45%; at least 1.3-fold (0.12 log units) between middle value and limit.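

Compound 4 gives > 20000 nM, which is a limit of the assay and not a number. In this assay, within the data shown here, cyclopropyl in place of 4-methylbenzyl gives an at least 3.2-fold higher number from compound 1 to compound 4 (0.51 log units; beyond the scatter), and since this nitrogen, like the one in compound 1, carries just one group besides the saturated chain carbon, the loss seen with compound 3 is not tied to the dimethylamino form of the amine. The step between compound 3 and compound 4 cannot be read, so these two replacements cannot be ranked: the limit of > 20000 nM in this assay, at which 2 of the 4 values shown sit.

The compounds shown leave open whether the aromatic ring of 4-methylbenzyl matters or just its larger carbon count. A plain benzyl, a cyclohexyl or a longer chain such as butyl on the same nitrogen would help separate the two.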